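Replacing the 3-carboxypyrrolidin-1-yl group of compound 2

A few compounds are considered here, and "the series" means these few. Any claim that something is new, unique, unknown or untested is made for them only; others in the source may bear on it.

Of the compounds shown here, two sharing one core have been tested so far, compound 1 (`COc1ccc(/C=C\c2cc(OC)c(OC)c(OC)c2)cc1OCc1ccc(CN2C[C@H](O)C[C@@H]2C(=O)O)cc1`) and compound 2 (`COc1ccc(/C=C\c2cc(OC)c(OC)c(OC)c2)cc1OCc1ccc(CN2CC[C@H](C(=O)O)C2)cc1`). In a functional assay on MC-38 cells (Mus musculus) for antiproliferative activity, read by CCK-8 assay, with a stated time of 48 h (a lower number here means a stronger inhibitor, a higher number a weaker inhibitor), compound 1 gives > 10000 nM, which is a limit of the assay and not a number. Compound 2 gives > 10000 nM, which is likewise a limit. The record so far is therefore (the limit of > 10000 nM in this assay, at which 2 of the 2 values shown sit), and compound 2 has no readable position.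

Compound 3 (`COc1ccc(/C=C\c2cc(OC)c(OC)c(OC)c2)cc1OCc1ccc(CNCCNC(C)=O)cc1`) has (2-acetamidoethyl)amino in place of 3-carboxypyrrolidin-1-yl on a saturated chain carbon bound to an aromatic carbon. For the measured compounds named here, the one measured step is a step that the two limits leave unreadable from compound 1 to compound 2, so it offers no size to carry over, and it changed only the pyrrolidine substituents, whereas this change removes the ring and the carboxy group together.

Any gain in this assay would have to come from this new side chain, and a move toward stronger inhibition is expected only tentatively. The expected step is an at least 2.0-fold lower number from compound 2 to compound 3 (0.30 log units; that floor lies within the scatter), a rough estimate. For compound 3 the estimated value is 5000 nM, with an expected range of 600 nM to 20000 nM.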

Compound 3, half-maximal inhibitory concentration: 1800 nM
The estimate for compound 3 lay 2.8-fold (0.44 log units) above the measured number; low and high end bracket the measured number.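

The position on the saturated chain carbon bound to an aromatic carbon can move the read-out: in this assay compound 3, with its open-chain (2-acetamidoethyl)amino group, gives 1800 nM, the only readable number among the compounds shown. The change amounts to an at least 5.5-fold lower number from compound 2 to compound 3 (0.74 log units; beyond the scatter), and the same group in place of 2-carboxy-4-hydroxypyrrolidin-1-yl amounts to an at least 5.5-fold lower number from compound 1 to compound 3 (0.74 log units; beyond the scatter); both steps lie beyond the scatter, but each is only a lower bound on the true size. Compound 1 and compound 2 both remain at a limit of the assay, not a number: the limit of > 10000 nM in this assay, at which 2 of the 3 values shown sit.

The change removes the ring and the carboxy group and brings in the acetamide all at once, so the compounds shown do not separate what each of these parts contributes. Open questions are how an unsubstituted pyrrolidine with no carboxylic acid would read at this position, and whether a plain primary amine or a longer chain ending in the same acetamide would give a lower or a higher number than compound 3.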